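A few compounds are considered here, and "the series" means these few. Any claim that something is new, unique, unknown or untested is made for them only; others in the source may bear on it.

In a functional assay on ECa-109 cells for inhibition, with ECa-109 cell line (Homo sapiens) as the target, read by sulforhodamine B assay (on this read-out lower numbers stand for stronger inhibition and higher numbers for weaker inhibition), compound 3 `COc1ccccc1NC1=CC(=O)c2nc3n(c2C1=O)[C@H]1OC[C@@H](O)[C@H]1OC3` stands only at a limit, > 4000 nM. The numbered neighbours are compound 1 `O=C1C=C(Nc2ccccc2F)C(=O)c2c1nc1n2[C@H]2OC[C@@H](O)[C@H]2OC1` at 2760 nM and compound 2 `O=C1C=C(Nc2cccc(F)c2)C(=O)c2c1nc1n2[C@H]2OC[C@@H](O)[C@H]2OC1` at 7030 nM. Compound 4 `CCOc1ccc(NC2=CC(=O)c3nc4n(c3C2=O)[C@H]2OC[C@@H](O)[C@H]2OC4)cc1` carries 4-ethoxyphenyl in place of 2-methoxyphenyl on an amine nitrogen. Among the compounds with values here, two measured steps bear on this change. Moving the fluoro group gave a 2.5-fold higher number from compound 1 to compound 2 (0.41 log units; beyond the scatter), a modest step beyond the scatter. Methoxy in place of fluoro gave an at least 1.4-fold higher number from compound 1 to compound 3 (0.16 log units; that floor lies within the scatter), whose floor lies within the scatter. Neither step covers an ethoxy group, so at most a modest shift towards weaker inhibition is expected. The expected change is a step that the limit leaves unreadable from compound 3 to compound 4. For compound 4 the estimated value is 6000 nM, with an expected range of 2500 nM to 14000 nM.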

Compound 4, half-maximal inhibitory concentration: 3210 nM
Compound 4: the middle estimate sits 1.9-fold (0.27 log units) above what was measured, within the range that was stated.
By their numbers in this assay, from the lowest: compounds 1 and 4 (each within the scatter of the next); then compound 2.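

Within the data shown here, compound 3 remains only a limit in this assay, which leaves 4-ethoxyphenyl as the only exact reading for an ether-bearing phenyl on this amine nitrogen: the limit of > 4000 nM in this assay, at which 1 of the 4 values shown sits. Against the limit the change gives an at least 1.2-fold lower number from compound 3 to compound 4 (0.09 log units; that floor lies within the scatter), while against 2-fluorophenyl it gives a 1.2-fold higher number from compound 1 to compound 4 (0.07 log units; within the scatter), so these two groups cannot be told apart here. Against 3-fluorophenyl it gives a 2.2-fold lower number from compound 2 to compound 4 (0.34 log units; beyond the scatter), so the ethoxy group keeps the number level with the better fluoro compound.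

The compounds shown do not separate the ethoxy group from its placement, as a 2-ethoxyphenyl or 4-methoxyphenyl pair would. Going by these compounds, whether a longer chain such as 4-propoxyphenyl holds this level stays open.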